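Halogen swap on the sugar ring of a cytosine nucleoside

A few compounds are considered here, and "the series" means these few. Any claim that something is new, unique, unknown or untested is made for them only; others in the source may bear on it.

Compound 1: `Nc1nc(=O)n(C2OC(CO)C(Cl)C2O)cc1F` — 0.7 ug/mL
Compound 2: `Nc1ccn(C2OC(CO)C(I)C2O)c(=O)n1` — 0.3 ug/mL

Of the compounds shown here, two have been measured in a functional assay on P815 cells (Mus musculus) for antiproliferative activity; a higher number here means a weaker inhibitor, a lower number a stronger inhibitor. Compound 1 gives 0.7 ug/mL, and compound 2 gives 0.3 ug/mL. Of the two, compound 2 has the lower number, and compound 1 stands higher by a gap that lies beyond the usual scatter. Going by the values given here, no single-change step between these two measured compounds exists, since they differ from each other in more than one place, so their two values can only be set side by side.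

Compound 3 is `Nc1ccn(C2OC(CO)C(Cl)C2O)c(=O)n1`, not yet measured in this assay. It is reached from compound 2 by one change: chloro in place of iodo on a saturated ring carbon. The measured pair gives no direct guide to the size of this particular swap. A small step is expected, leaning towards a somewhat higher number, with a 1.7-fold higher number from compound 2 to compound 3 (0.22 log units; within the scatter) as the estimated step from compound 2 to compound 3, which may well stay within the scatter. Compound 3 is therefore expected to give about 0.5 ug/mL, within a range from 0.15 ug/mL to 1.5 ug/mL.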

Compound 3, concentration for 50% inhibition: 0.8 ug/mL
The estimate for compound 3 lay 1.6-fold (0.20 log units) below the measured number, within the range that was stated.
By their numbers in this assay, from the lowest: compound 2; then compounds 1 and 3 (each within the scatter of the next).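

Going by these compounds alone, putting chloro in place of iodo on a saturated ring carbon gives a 2.7-fold higher number from compound 2 to compound 3 (0.43 log units; beyond the scatter) in this assay, so this is the first direct sign that the identity of the halogen at this position registers in the read-out, which the earlier pair, differing in more than one place, could not show. Compound 3 also provides the link to compound 1 that was missing: hydrogen in place of fluoro on an aromatic carbon gives a 1.1-fold higher number from compound 1 to compound 3 (0.06 log units; within the scatter), so with chloro held on the saturated ring carbon, this change does not separate the two compounds beyond the scatter. Nothing available here bears on why the swap of iodo for chloro shifts the number.

As far as these compounds go, the position is covered by only two halogens, so it remains open how bromo, a hydroxy group or an amine on the same ring carbon would read, and whether the step follows any order across such groups. From the compounds shown here alone, it also remains open whether fluoro on the aromatic carbon would give a similarly small step with iodo on the saturated ring carbon instead of chloro.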